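Para-substituent variation on the biphenyl-pyrazole series

A few compounds are considered here, and "the series" means these few. Any claim that something is new, unique, unknown or untested is made for them only; others in the source may bear on it.

Measured compounds:
compound 1 `COc1ccc(-c2cc(-c3ccccc3-c3ccccc3)n[nH]2)cc1` — 790 nM
compound 2 `FC(F)(F)c1ccc(-c2cc(-c3ccccc3-c3ccccc3)n[nH]2)cc1` — 6900 nM
compound 3 `Oc1ccc(-c2cc(-c3ccccc3-c3ccccc3)n[nH]2)cc1` — 9200 nM

In a functional assay on AGS cells (Homo sapiens) for inhibition, read by MTT assay, with a stated time of 48 h (a lower number here means a stronger inhibitor of growth, a higher number a weaker inhibitor of growth), compound 3 gives 9200 nM, the highest number of the three. Its nearest neighbour is compound 2: a 1.3-fold higher number from compound 2 to compound 3 (0.12 log units; within the scatter). The gap to compound 1 is wider: a 12-fold higher number from compound 1 to compound 3 (1.07 log units; beyond the scatter).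

Compound 4 `O=[N+]([O-])c1ccc(-c2cc(-c3ccccc3-c3ccccc3)n[nH]2)cc1` has not yet been measured in this assay. It differs from compound 3 in one place: nitro in place of hydroxy on an aromatic carbon, on an aromatic carbon of a six-membered aromatic ring of carbon only, para to a large group. Going by the values given here, no measured step exchanges a hydroxy for a nitro. Among the compounds with values here, the steps that bear on the question are those that alter the same position: an 8.7-fold higher number from compound 1 to compound 2 (0.94 log units; beyond the scatter), a 12-fold higher number from compound 1 to compound 3 (1.07 log units; beyond the scatter) and a 1.3-fold higher number from compound 2 to compound 3 (0.12 log units; within the scatter). The first two show that the group at this position can move the number widely; the third shows that two quite different groups can also sit within the scatter of each other. With nothing directly comparable, the expected outcome for compound 4 is a step of modest size or none beyond the scatter, a 1.5-fold lower number from compound 3 to compound 4 (0.19 log units; within the scatter), with wide uncertainty. Compound 4 is therefore estimated at 6000 nM in this assay, with a range from 1500 nM to 20000 nM.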

Compound 4, concentration for 50% growth inhibition: 1200 nM
For compound 4 the middle estimate is 5.0-fold (0.70 log units) above the measured one; the measured number lies below the stated range.
By their numbers in this assay, from the lowest: compounds 1 and 4 (each within the scatter of the next); then compounds 2 and 3 (each within the scatter of the next).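

In this assay nitro in place of hydroxy gives a 7.7-fold lower number from compound 3 to compound 4 (0.88 log units; beyond the scatter) and nitro in place of trifluoromethyl gives a 5.8-fold lower number from compound 2 to compound 4 (0.76 log units; beyond the scatter) while nitro in place of methoxy gives a 1.5-fold higher number from compound 1 to compound 4 (0.18 log units; within the scatter) and so stays within the scatter. Compound 1 therefore no longer stands alone at this position: the four groups now fall into two sets, with compound 1 and compound 4 in one and compound 2 and compound 3 in the other. Nothing available on these compounds explains why each group falls into its set.

Four groups on an aromatic carbon para to a large group are too few to give a rule for this position. From the compounds shown here alone, whether an amine, a nitrile or a carboxylic acid there would join compound 1 and compound 4 or compound 2 and compound 3 remains open.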